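This account rests on a few compounds, and the source may have more. Where it says the series, first, only, none or still open, it means among the compounds named here.

Measured in an in vivo functional assay on the whole organism for inhibition, with Rattus norvegicus as the target; on this read-out lower numbers stand for an effect already at smaller amounts and higher numbers for an effect only at larger amounts of compound:
- compound 1 `CCCCc1nc(C)c(CC(=O)N2CCCC2)c(=O)n1Cc1ccc(-c2ccccc2-c2nnn[nH]2)cc1`: 0.056 mg/kg
- compound 2 `CCCCc1nc(C)c(CC(=O)N2CCC[C@H]2C(N)=O)c(=O)n1Cc1ccc(-c2ccccc2-c2nnn[nH]2)cc1`: 0.023 mg/kg
- compound 3 `CCCCc1nc(C)c(CC(=O)N2CCSCC2)c(=O)n1Cc1ccc(-c2ccccc2-c2nnn[nH]2)cc1`: 0.038 mg/kg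

Compound 3 sits within the scatter of both others, with a 1.5-fold lower number from compound 1 to compound 3 (0.17 log units; within the scatter) and a 1.7-fold higher number from compound 2 to compound 3 (0.22 log units; within the scatter). Compound 4 `CCCCc1nc(C)c(CCC(=O)N2CC(C)OC(C)C2)c(=O)n1Cc1ccc(-c2ccccc2-c2nnn[nH]2)cc1` carries ((2,6-dimethylmorpholin-4-yl)carbonyl)methyl in place of (thiomorpholin-4-yl)carbonyl on a saturated chain carbon bound to an aromatic carbon. The measured steps change only the ring group on the carbonyl carbon, and the largest, a 2.4-fold lower number from compound 1 to compound 2 (0.39 log units; beyond the scatter), is modest. Among the measured compounds shown here, no measured compound has the longer chain, so that part of the change is untested. In this assay a shift toward a higher number, not clearly beyond the scatter, is therefore expected. The expected step is a 1.6-fold higher number from compound 3 to compound 4 (0.20 log units; within the scatter). For compound 4 the estimate is 0.06 mg/kg, with an expected range of 0.015 mg/kg to 0.25 mg/kg.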

Compound 4, dose for half-maximal effect: 0.228 mg/kg
Compound 4: middle estimate off by 3.8-fold (0.58 log units), on the low side; low and high end bracket the measured number.
By their numbers in this assay, from the lowest: compounds 2, 3 and 1 (each within the scatter of the next, the first and the last beyond it); then compound 4.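

In this assay the earlier changes touched only the ring group on the carbonyl carbon, whereas this one lengthens the chain and changes the ring together. It gives a 6.0-fold higher number from compound 3 to compound 4 (0.78 log units; beyond the scatter) and a 4.1-fold higher number from compound 1 to compound 4 (0.61 log units; beyond the scatter) and also a 9.9-fold higher number from compound 2 to compound 4 (1.00 log units; beyond the scatter), so the number rises beyond the scatter against all three earlier compounds. No measurement available here accounts for this shift.

The compounds leave open whether the longer chain or the 2,6-dimethylmorpholin-4-yl ring drives it. Pairing 2-((thiomorpholin-4-yl)carbonyl)ethyl with ((2,6-dimethylmorpholin-4-yl)carbonyl)methyl would separate the two, and a carboxylic acid on this chain remains open too.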